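The source may hold more compounds than are shown below. What is called first, only, known or untested is meant among the compounds shown, and "the series" means these compounds.

Measured in an ADME assay on GES1 cells (Homo sapiens) for inhibition, read by MTT assay, with a stated time of 72 h; on this read-out higher numbers stand for weaker inhibition and lower numbers for stronger inhibition:
- compound 1 `Cc1cc(Nc2cc(-c3ccccc3)[nH]n2)n2nc(SCCc3ccccc3)nc2n1`: 37400 nM
- compound 2 `C#CCSc1nc2nc(C)cc(Nc3cc(-c4ccccc4)[nH]n3)n2n1`: 45700 nM

Compound 2 stands level with compound 1, as their two values lie within the scatter of each other. Compound 3 `Cc1cc(Nc2cc(-c3ccccc3)[nH]n2)n2nc(SCc3nc4ccccc4[nH]3)nc2n1` differs from compound 2 as follows: 1H-benzimidazol-2-yl in place of ethynyl on a saturated chain carbon bound to a sulfur. Among the measured compounds shown here, the only measured step at this place is a 1.2-fold higher number from compound 1 to compound 2 (0.09 log units; within the scatter), with ethynyl in place of benzyl. One step is thin evidence and says nothing directly about 1H-benzimidazol-2-yl, so no shift beyond the scatter is expected in this assay. The expected step is a 1.2-fold lower number from compound 2 to compound 3 (0.08 log units; within the scatter). The estimate for compound 3 is 38000 nM, within a range of 17000 nM to 85000 nM.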

Compound 3, half-maximal inhibitory concentration: 27800 nM
The estimate for compound 3 lay 1.4-fold (0.14 log units) above the measured number, within the range that was stated.
By their numbers in this assay, from the lowest: compounds 3, 1 and 2 (each within the scatter of the next).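

In this assay putting 1H-benzimidazol-2-yl on a saturated chain carbon bound to a sulfur gives a 1.6-fold lower number from compound 2 to compound 3 (0.22 log units; within the scatter) when it replaces ethynyl and a 1.3-fold lower number from compound 1 to compound 3 (0.13 log units; within the scatter) when it replaces benzyl. This place therefore now holds a group with two aromatic rings, a hydrogen-bond donor and a hydrogen-bond acceptor, and the number still stays within the scatter of both earlier compounds. Whether an amine or a carboxylic acid at this place would move the number beyond the scatter remains open, and nothing available offers a reason for these numbers.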